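Methyl removal on the aryl ring of pyrrolidine acetic acids

This account rests on a few compounds, and the source may have more. Where it says the series, first, only, none or still open, it means among the compounds named here.

Compound 1 `O=C(O)C[C@@H]1CCCN1c1ccc(OCc2ccc(Cl)cc2Cl)cc1`, compound 2 `Cc1cc(OCc2ccc(Cl)cc2Cl)ccc1N1CCC[C@H]1CC(=O)O` and compound 3 `Cc1ccccc1Oc1ccc(N2CCC[C@H]2CC(=O)O)cc1` carry the same acetic acid bearing pyrrolidine; the difference between the cores of compound 3 and compound 2 is not broken down here. In a functional assay on cells for agonist activity at Free fatty acid receptor 1 (Mus musculus), read by FLIPR and calcium flux, with a stated time of 100 s (on this read-out higher numbers stand for an effect only at larger amounts of compound and lower numbers for an effect already at smaller amounts), compound 1 gives 4500 nM, compound 2 gives 14000 nM and compound 3 gives 5600 nM. The change hydrogen in place of methyl on an aromatic carbon produced the step of a 3.1-fold lower number from compound 2 to compound 1 (0.49 log units; beyond the scatter). Compound 4 `O=C(O)C[C@@H]1CCCN1c1ccc(Oc2ccccc2)cc1` is unmeasured and differs from compound 3 by hydrogen in place of methyl on an aromatic carbon, the same kind of change; the surroundings differ, since in compound 2 the methyl is ortho to a group of 9 heavy atoms and meta to a large group, while in compound 3 it is ortho to a large group. A step of a 2.2-fold lower number from compound 3 to compound 4 (0.35 log units; beyond the scatter) is expected, resting on the earlier step of a 3.1-fold lower number from compound 2 to compound 1 (0.49 log units; beyond the scatter) seen for this kind of change, with wide uncertainty given the different place. Compound 4 is therefore estimated at 2500 nM, likely between 800 nM and 8000 nM.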

Compound 4, half-maximal effective concentration: > 16000 nM
Compound 4: no number, only a limit (the forecaster's own chance of this, stated with the estimate: 5%); middle value at least 6.4-fold (0.80 log units) away from the limit.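

On the core of compound 3, hydrogen in place of methyl gives an at least 2.8-fold higher number from compound 3 to compound 4 (0.45 log units; beyond the scatter) in this assay, so the change does not carry from one core to the other, not even in direction: the same change on two cores in this assay, a 3.1-fold lower number (0.49 log units; beyond the scatter) from compound 2 to compound 1 and an at least 2.8-fold higher number (0.45 log units; beyond the scatter) from compound 3 to compound 4, at least 8.8-fold (0.94 log units) apart, beyond the scatter of two such steps

Compound 4 gives only a limit, so the size of this step stays open: the limit of > 16000 nM in this assay, at which 1 of the 4 values shown sits.

These two pairs show that the outcome of this change differs with the core; they do not show which feature of the cores sets that difference, and the methyl also stands in a different place in each pair.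

Open, as far as these compounds go, is whether an ethyl, a methoxy or a fluorine in place of the methyl of the 2-methylphenyl group would follow compound 3 or compound 4.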